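Replacing tert-butoxycarbonyl with ethyl in compound 3

The source may hold more compounds than are shown below. What is called first, only, known or untested is meant among the compounds shown, and "the series" means these compounds.

Of the compounds shown here, three sharing one core have been measured in a functional assay on KYSE-450 cells (Homo sapiens) for inhibition, read by CCK-8 assay, with a stated time of 48 h; a higher number here means a weaker inhibitor, a lower number a stronger inhibitor. Compound 1 `COc1cc(N(Cc2ccc(Cl)cc2)C(=O)CSC(=S)N2CCN(C(=O)OC(C)(C)C)CC2)cc(OC)c1OC` gives 11900 nM, compound 2 `COc1ccc(CN(C(=O)CSC(=S)N2CCN(C(=O)OC(C)(C)C)CC2)c2cc(OC)c(OC)c(OC)c2)cc1F` gives 2410 nM, and compound 3 `COc1ccc(CN(C(=O)CSC(=S)N2CCN(C(=O)OC(C)(C)C)CC2)c2cc(OC)c(OC)c(OC)c2)cc1O` gives 76 nM. Compound 3 therefore has the lowest number of the three, and its gaps to both others lie beyond the scatter. Placing 3-fluoro-4-methoxyphenyl where 4-chlorophenyl stood gave a 4.9-fold lower number from compound 1 to compound 2 (0.69 log units; beyond the scatter), a modest step. Placing 3-hydroxy-4-methoxyphenyl there gave a 160-fold lower number from compound 1 to compound 3 (2.19 log units; beyond the scatter), and hydroxy in place of fluoro on an aromatic carbon gave a 32-fold lower number from compound 2 to compound 3 (1.50 log units; beyond the scatter), both large steps.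

Compound 4 `CCN1CCN(C(=S)SCC(=O)N(Cc2ccc(OC)c(O)c2)c2cc(OC)c(OC)c(OC)c2)CC1` keeps the 3-hydroxy-4-methoxyphenyl group and carries ethyl in place of tert-butoxycarbonyl on an amine nitrogen in a ring. None of the three measured steps touches that nitrogen, so they give neither a size nor a direction for this change. Among the compounds with values here, the only anchor is compound 3 at 76 nM. With no measured guide, no step beyond the scatter is expected, although the uncertainty is wide, and the estimated change is a 1.3-fold higher number from compound 3 to compound 4 (0.12 log units; within the scatter). For compound 4 the expected value in this assay is 100 nM, with an estimated range from 15 nM to 700 nM.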

Compound 4, half-maximal inhibitory concentration: 320 nM
For compound 4 the middle estimate is 3.2-fold (0.51 log units) below the measured one; measured number inside the range.
By their numbers in this assay, from the lowest: compound 3; then compound 4; then compound 2; then compound 1.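

Within the data shown here, the amine nitrogen in the six-membered ring, untouched by the earlier steps, proves to matter: in this assay, ethyl in place of tert-butoxycarbonyl gives a 4.2-fold higher number from compound 3 to compound 4 (0.62 log units; beyond the scatter), a modest step that lies beyond the scatter. This exchange swaps a group of 7 heavy atoms and 2 hydrogen-bond acceptors for one of 2 heavy atoms and none, so the direction at this position is now known for one pair: the smaller group gives the weaker inhibitor, though the low number of compound 3 does not rest entirely on tert-butoxycarbonyl, since compound 4 remains at 320 nM. No measurement given here accounts for this change in the number.

The compounds shown leave open how the number would respond on that nitrogen to a bare ring amine bearing hydrogen, to an acetyl group, or to a longer chain such as butyl, any of which would help show whether size or the carbonyl of the leaving group tracks with the step. They also leave open whether the same exchange would give a step of similar size alongside 4-chlorophenyl or 3-fluoro-4-methoxyphenyl.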